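This account rests on a few compounds, and the source may have more. Where it says the series, first, only, none or still open, it means among the compounds named here.

Measured compounds:

- compound 1, `CCN(CC)CN1C(=O)/C(=N\c2nc3ccc(C)cc3s2)c2c(Br)cccc21`: 28700 nM
- compound 2, `O=C1C(=O)N(CN2CCCCC2)c2cccc(Br)c21`: 30200 nM
- compound 3, `O=C1C(=O)N(CN2CCCCC2)c2cccc(Cl)c21`: 26500 nM

All three numbers come from a functional assay on MDA-MB-231 cells (Homo sapiens) for cytotoxicity, read by sulforhodamine B assay, with a stated time of 48 h; on this read-out higher numbers stand for weaker inhibition of growth and lower numbers for stronger inhibition of growth. In this assay compound 1 gives 28700 nM, compound 2 gives 30200 nM and compound 3 gives 26500 nM; the three lie within the scatter of one another, so no order among them is claimed.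

Compound 2 and compound 3 differ in one place, (chloro in place of bromo on an aromatic carbon). That pair gives a 1.1-fold lower number from compound 2 to compound 3 (0.06 log units; within the scatter). Compound 1 carries a different core; how it differs from compound 2 is not broken down here.

The unmeasured compound 4, `CCN(CC)CN1C(=O)/C(=N\c2nc3ccc(C)cc3s2)c2c(Cl)cccc21`, relates to compound 1 exactly as compound 3 relates to compound 2: the change is chloro in place of bromo on an aromatic carbon, the same change at the same kind of place. Within the data shown here, the only measured instance of this change, from compound 2 to compound 3, sits within the scatter, so the expectation for compound 4 rests on that single pair and on the value of compound 1, 28700 nM. An estimated step of a 1.1-fold lower number from compound 1 to compound 4 (0.03 log units; within the scatter) is expected from compound 1 to compound 4 in this assay, because the measured step of a 1.1-fold lower number from compound 2 to compound 3 (0.06 log units; within the scatter) was of that size. For compound 4 the estimated value in this assay is 27000 nM, expected to fall between 14000 nM and 55000 nM.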

Compound 4, concentration for 50% growth inhibition: 20400 nM
For compound 4 the middle estimate is 1.3-fold (0.12 log units) above the measured one, within the range that was stated.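

On the core of compound 1, chloro in place of bromo on an aromatic carbon gives a 1.4-fold lower number from compound 1 to compound 4 (0.15 log units; within the scatter) in this assay, and set beside the step on the other core, the two agree: the same change on two cores in this assay, a 1.1-fold lower number (0.06 log units; within the scatter) from compound 2 to compound 3 and a 1.4-fold lower number (0.15 log units; within the scatter) from compound 1 to compound 4, 1.2-fold (0.09 log units) apart, within the scatter of two such steps. Among these compounds, the reading that carries from one core to the other is therefore a limited one: on both cores this exchange of one halogen for the other leaves the number within the scatter, and no step that can be read appears on either. This does not show that bromo and chloro differ in this assay, nor does it show that they are interchangeable in general, and two pairs on two cores give no rule for any further core.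

The compounds shown carry only bromo or chloro at this aromatic carbon, so it remains open whether fluoro, methoxy, a nitrile or an amine at that place would give a step beyond the scatter. From the compounds shown here alone, it also remains open whether the halogen exchange would stay this small on a core bearing a morpholine or a carboxylic acid, and whether it would do so in any other assay.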